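Compound 4 against compound 3: isopropyl at the chain carbon

The source may report more compounds than this note shows. Statements on the series, on what has been measured and on what is new or still open speak of the compounds shown alone.

Compound 3 `COc1cc(C(=O)NC2CCN(C)CC2)ccc1Nc1ncc2c(n1)N(C1CCCC1)[C@H](C)C(=O)N2C` gives 1.1 nM in an assay on isolated protein for inhibition of serine/threonine-protein kinase PLK1 (Homo sapiens), read by Z'-LYTE (on this read-out lower numbers stand for stronger inhibition and higher numbers for weaker inhibition), the lowest number among the three measured compounds. Compound 2 `CC[C@@H]1C(=O)Nc2cnc(Nc3ccc(C(=O)NC4CCN(C)CC4)cc3OC)nc2N1C1CCCCC1` gives 37.2 nM in this assay, and compound 1 `CC[C@@H]1C(=O)Nc2cnc(Nc3ccc(C(=O)NC4CCN(C)CC4)cc3OC)nc2N1C(C)C` gives 2620 nM in this assay. For the measured compounds named here, the only single-point step measured is a 70-fold lower number from compound 1 to compound 2 (1.85 log units; beyond the scatter); it concerns the group on the ring nitrogen, not the chain carbon. Going by the values given here, compound 3 and compound 2 differ in several places at once, so their two values are noted but give no step for the position in question. Compound 4 `COc1cc(C(=O)NC2CCN(C)CC2)ccc1Nc1ncc2c(n1)N(C1CCCC1)[C@H](CC(C)C)C(=O)N2C` differs from compound 3 by isopropyl in place of hydrogen on a saturated chain carbon bound to a saturated ring carbon. Among the compounds with values here, no measured step touches this carbon, and the one step recorded lies elsewhere and cannot be carried over. For compound 4 in this assay the expectation is therefore a step within or only just beyond the scatter, more likely toward a higher number, a 2.3-fold higher number from compound 3 to compound 4 (0.36 log units; beyond the scatter). Compound 4 is estimated at 2.5 nM, with a range from 0.7 nM to 10 nM.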

Compound 4, half-maximal inhibitory concentration: 78 nM
Compound 4: the middle estimate sits 31-fold (1.49 log units) below what was measured; the whole stated range lies below it.
By their numbers in this assay, from the lowest: compound 3; then compound 2; then compound 4; then compound 1.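

In this assay the change from methyl to isobutyl on this saturated chain carbon bound to a saturated ring carbon gives a 71-fold higher number from compound 3 to compound 4 (1.85 log units; beyond the scatter) as the first step read at this carbon, so the number here depends strongly on the group the carbon carries. This added isopropyl moves the number about as far as the change on the ring nitrogen does in the opposite direction, seen in a 70-fold lower number from compound 1 to compound 2 (1.85 log units; beyond the scatter) and now showing two single-place changes of large size in the series. Nothing available accounts for the step from compound 3 to compound 4.

On these data alone, whether hydroxymethyl or aminomethyl on this carbon would give a number nearer that of compound 3 or of compound 4 remains open. Also open, as far as these compounds go, is how a phenyl or a longer chain here would read, so one step gives no trend with group size at this carbon.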